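A few compounds are considered here, and "the series" means these few. Any claim that something is new, unique, unknown or untested is made for them only; others in the source may bear on it.

For the measured compounds named here, in a functional assay on HCC827 cells (Homo sapiens) for antiproliferative activity, read by MTT assay, with a stated time of 72 h (a higher number here means a weaker inhibitor, a lower number a stronger inhibitor), only one compound has so far given a true number. Going by the values given here, compound 3 `O=C(O)CCC(=O)Nc1cc(Nc2ccc(Cl)cc2)ncn1` gives 3130 nM and is the only measured number available. Compound 1 `O=C(Nc1cc(Nc2ccc(Cl)cc2)ncn1)c1ccc(F)cc1` reads > 30000 nM, which is a limit of the assay and not a number. Compound 2 `CCOC(=O)CCCC(=O)Nc1cc(Nc2cccc(Cl)c2)ncn1` reads > 30000 nM, which is likewise a limit. The picture so far is therefore dominated by the limit of > 30000 nM in this assay, at which 2 of the 3 values shown sit, so compound 3 can be compared with the others only against that limit.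

Compound 4 `Clc1ccc(Nc2cc(Nc3cccc(Cl)n3)ncn2)cc1` has not yet been measured. It differs from compound 3 as follows: 6-chloropyridin-2-yl in place of (2-carboxyethyl)carbonyl on a nitrogen on an aromatic ring. In words, 6-chloropyridin-2-yl stands in place of (2-carboxyethyl)carbonyl on a nitrogen on an aromatic ring.

Among the compounds with values here, only one measured step bears on this change: an at least 9.5-fold lower number from compound 1 to compound 3 (0.98 log units; beyond the scatter), a shift beyond the scatter that put 2-carboxyethyl in place of 4-fluorophenyl on a carbonyl carbon. Compound 4 goes the opposite way in kind, losing 2-carboxyethyl and gaining an aromatic ring, although at a different attachment point, so a move towards a higher number seems likely. The expected step is a 4.5-fold higher number from compound 3 to compound 4 (0.65 log units; beyond the scatter), meaning weaker inhibition in this assay, and a result at the limit would be no surprise. For compound 4 the estimated value is 14000 nM, with an expected range from 3500 nM to 50000 nM.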

Compound 4, half-maximal inhibitory concentration: > 30000 nM
Compound 4 was reported as a limit; the forecaster's own chance of this, stated with the estimate: 40%; at least 2.1-fold (0.33 log units) between middle value and limit.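

In this assay, placing 6-chloropyridin-2-yl where (2-carboxyethyl)carbonyl stood, on a nitrogen on an aromatic ring, gives an at least 9.5-fold higher number from compound 3 to compound 4 (0.98 log units; beyond the scatter), and this change removes the carbonyl itself, which the earlier step, confined to a swap on the carbonyl carbon, left in place. Compound 4 gives > 30000 nM, which is a limit of the assay and not a number, so the step sets only a minimum size and the true gap could be larger. Compound 3 remains the only compound with a true number, and the others cannot be ranked against one another: the limit of > 30000 nM in this assay, at which 3 of the 4 values shown sit.

The compounds shown do not separate the role of the carbonyl from that of the carboxylic acid at the end of the chain, since compound 2, which carries an ethyl ester on a longer chain, also differs from compound 3 in the place of its chlorine. From the compounds shown here alone, whether the number would fall further with a longer chain ending in a carboxylic acid, or shift with an amine at the end of the chain, remains open.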